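A few compounds are considered here, and "the series" means these few. Any claim that something is new, unique, unknown or untested is made for them only; others in the source may bear on it.

Of the compounds shown here, three have been measured so far. Compound 1, `CC(O)(CSc1ccc(S(F)(F)(F)(F)F)cc1)C(=O)Nc1cccc(S(F)(F)(F)(F)F)c1`, gives 13100 nM in a functional assay on CWR22R cells (Homo sapiens) for antiproliferative activity, read by propidium iodide staining, with a stated time of 96 h; a lower number here means a stronger inhibitor, a higher number a weaker inhibitor. Compound 2, `CC(O)(CSc1ccc(F)cc1)C(=O)Nc1cccc(S(F)(F)(F)(F)F)c1`, shares the core of compound 1 and differs from it by one fluorine atom in place of a group of 6 heavy atoms (5 fluorine, 1 sulfur; no ring), on an aromatic carbon. In this assay compound 2 gives 30200 nM. The step between the two is a 2.3-fold higher number from compound 1 to compound 2 (0.36 log units; beyond the scatter). Compound 3, `CC(O)(CS(=O)(=O)c1ccc(S(F)(F)(F)(F)F)cc1)C(=O)Nc1ccc(S(F)(F)(F)(F)F)cc1`, rests on a different core, and how that core differs from the core of compound 1 is not broken down here. In this assay compound 3 gives 17300 nM, a number that stands within the scatter of the number of compound 1 and within the scatter of the number of compound 2.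

Compound 4, `CC(O)(CS(=O)(=O)c1ccc(F)cc1)C(=O)Nc1ccc(S(F)(F)(F)(F)F)cc1`, has not yet been measured. It differs from compound 3 by one fluorine atom in place of a group of 6 heavy atoms (5 fluorine, 1 sulfur; no ring), on an aromatic carbon. This is the same change that separates compound 1 from compound 2, and it occurs twice among these four compounds. Within the data shown here, only one measured instance of it exists, so the expectation for compound 4 rests on that single step. Among the measured compounds shown here, because the earlier instance gave a 2.3-fold higher number from compound 1 to compound 2 (0.36 log units; beyond the scatter), the expected step here is a 2.3-fold higher number from compound 3 to compound 4 (0.36 log units; beyond the scatter), with a wider spread kept in mind since there is only one precedent. In this assay compound 4 is expected to give about 40000 nM, most likely between 20000 nM and 80000 nM.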

Compound 4, half-maximal inhibitory concentration: 20600 nM
Compound 4: the middle estimate sits 1.9-fold (0.29 log units) above what was measured; measured number inside the range.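

On the core of compound 3, setting fluoro in place of the group of 6 heavy atoms (5 fluorine, 1 sulfur) on the aromatic carbon gives, in this assay, a 1.2-fold higher number from compound 3 to compound 4 (0.08 log units; within the scatter), so on this core the exchange leaves no effect that can be told apart from the scatter of repeated measurements. Among these compounds, the step does not differ from its precedent by more than such measurements allow, so the pair offers no sign that the core alters what this change does: the same change on two cores in this assay, a 2.3-fold higher number (0.36 log units; beyond the scatter) from compound 1 to compound 2 and a 1.2-fold higher number (0.08 log units; within the scatter) from compound 3 to compound 4, 1.9-fold (0.29 log units) apart, within the scatter of two such steps This does not show that the change transfers reliably, since it rests on only two pairs of compounds, only one of the two steps lies beyond the scatter, and the two cores cannot be said to behave alike or differently in any finer way.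

The compounds shown carry only fluoro or the group of 6 heavy atoms on that aromatic carbon, so what a trifluoromethyl group, a nitrile or an amine would give there remains open. Also open, on these data alone, is how the same change would read on a core bearing a carboxylic acid, or a longer chain in place of the methyl group.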